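This account rests on a few compounds, and the source may have more. Where it says the series, first, only, none or still open, it means among the compounds named here.

Measured compounds in an ADME assay on CCRF-HSB-2 cells (Homo sapiens) for cytotoxicity, with a stated time of 7 days; a higher number here means that more compound is tolerated, a lower number that less compound is tolerated:

Compound 1, `Nc1nc(N2CCCC2)c2ncn(/C=C3/CC3(CO)CO)c2n1`, gives > 20000 nM, which is a limit of the assay rather than a number.
Compound 2, `Nc1nc2c(ncn2/C=C2/CC2(CO)CO)c(=O)[nH]1`, gives > 20000 nM, again a limit and not a number.
Compound 3, `C=CCOc1nc(N)nc2c1ncn2/C=C1/CC1(CO)CO`, gives > 20000 nM, once more a limit and not a number.

Compound 1 therefore stands at the edge of what this assay can report, and it shares that position with the other two measured compounds: the limit of > 20000 nM in this assay, at which 3 of the 3 values shown sit. For the measured compounds named here, no measured compound shows a readable number, so no ordering among them can be drawn.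

The compound still to be tested is compound 4, `CC(C)Sc1nc(N)nc2c1ncn2/C=C1/CC1(CO)CO`. It differs from compound 1 in a single place: isopropylsulfanyl in place of pyrrolidin-1-yl on an aromatic carbon.

Going by the values given here, only one measured step touches the same place on the shared core, a step that the two limits leave unreadable from compound 1 to compound 3. Both of its ends are limits, so it runs from one limit to the same limit and gives no size and no direction. The measured steps thus offer no evidence for any change in this assay beyond the usual scatter, and none for a change within it either.

On that basis compound 4 is expected to give 20000 nM, with a range from 10000 nM to 40000 nM, most likely reported as a limit again. The step this estimate implies is expected to be a number no higher from compound 1 to compound 4 (the limit leaves the size open).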

Compound 4, half-maximal cytotoxic concentration: 94000 nM
The estimate for compound 4 lay 4.7-fold (0.67 log units) below the measured number; the measured number lies above the stated range.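

In this assay, the steps linking compound 4 to compound 1 and to compound 3 cannot be read, because those two compounds give a limit and not a number: the limit of > 20000 nM in this assay, at which 3 of the 4 values shown sit.

What the compounds shown leave open is how far isopropylsulfanyl, allyloxy and pyrrolidin-1-yl on this aromatic carbon actually differ from one another.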